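A few compounds are considered here, and "the series" means these few. Any claim that something is new, unique, unknown or untested is made for them only; others in the source may bear on it.

Compound 2 `CCCc1nnc(SCC(=O)c2ccc(C)cc2)n1N1C(=O)c2ccccc2C1=O` belongs to a small set built on one shared core, which compound 1 `C=CCSc1nnc(CCC)n1N1C(=O)c2ccccc2C1=O` also carries. In a functional assay on MKN-45 cells (Homo sapiens) for cytotoxicity, read by MTT assay, with a stated time of 48 h (on this read-out higher numbers stand for weaker inhibition and lower numbers for stronger inhibition), compound 1 gives > 200000 nM, a limit of the assay rather than a number. In this assay compound 2 likewise gives > 200000 nM, again a limit and not a measured value. Among the measured compounds shown here, the single step between these two, a step that the two limits leave unreadable from compound 1 to compound 2, therefore cannot be read in size, since the limit of > 200000 nM in this assay, at which 2 of the 2 values shown sit, marks where both values sit. Compound 3 `CCCc1nnc(SC)n1N1C(=O)c2ccccc2C1=O` takes the change (hydrogen in place of (4-methylphenyl)carbonyl on a saturated chain carbon bound to a sulfur); the same difference, cut one bond further out, reads as ((4-methylphenyl)carbonyl)methyl to methyl. For the measured compounds named here, no measured step speaks to this change, and the one step in hand, from compound 1 to compound 2, is itself hidden by the two limits. With nothing pointing toward stronger inhibition, compound 3 is expected to remain at the limit in this assay, a step that the limit leaves unreadable from compound 2 to compound 3 being the expectation. Compound 3 is estimated at 300000 nM, within a range from 100000 nM to 1000000 nM.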

Compound 3, half-maximal inhibitory concentration: > 200000 nM
Compound 3 gave a limit, no number; the forecaster's own chance of this, stated with the estimate: 85%; the middle value does not contradict the limit.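

Among the compounds shown here, no step among compound 1, compound 2 and compound 3 can be read in size in this assay because all three values are limits of the assay and not numbers: the limit of > 200000 nM in this assay, at which 3 of the 3 values shown sit. The compounds shown leave open how far any group on a saturated chain carbon bound to a sulfur changes inhibition in this assay.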